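Thiourea in place of benzyl on the ring nitrogen

A few compounds are considered here, and "the series" means these few. Any claim that something is new, unique, unknown or untested is made for them only; others in the source may bear on it.

Measured so far:
compound 1, `NC(=O)c1c(NC(=O)c2ccccc2Cl)sc2c1CCNC2`, 18600 nM
compound 2, `NC(=O)c1c(NC(=O)c2ccccc2Cl)sc2c1CCN(Cc1ccccc1F)C2`, 21800 nM
compound 3, `NC(=O)c1c(NC(=O)c2ccccc2Cl)sc2c1CCN(Cc1c(Cl)cccc1Cl)C2`, 4850 nM

These three compounds share one core and differ only on an amine nitrogen in a ring. In a functional assay on HL-60 cells (Homo sapiens) for antiproliferative activity, with a stated time of 24 h (on this read-out higher numbers stand for weaker inhibition and lower numbers for stronger inhibition), compound 2 and compound 1 lie within the scatter of each other, as a 1.2-fold higher number from compound 1 to compound 2 (0.07 log units; within the scatter) shows, while compound 3 is set apart by a 4.5-fold lower number from compound 2 to compound 3 (0.65 log units; beyond the scatter). Compound 4, `NC(=O)c1c(NC(=O)c2ccccc2Cl)sc2c1CCN(C(=S)Nc1c(Cl)cccc1Cl)C2`, is not yet measured; its change from compound 2 is a group of 11 heavy atoms (7 carbon, 1 nitrogen, 1 sulfur, 2 chlorine; one six-membered aromatic ring of carbon only) in place of a group of 8 heavy atoms (7 carbon, 1 fluorine; one six-membered aromatic ring of carbon only), on an amine nitrogen in a ring. The step that bears most on it is a 4.5-fold lower number from compound 2 to compound 3 (0.65 log units; beyond the scatter), since the entering group also carries two chlorines on the aromatic ring, though here joined through a thiourea rather than a single carbon. A modest step toward a lower number is therefore expected, a 3.1-fold lower number from compound 2 to compound 4 (0.49 log units; beyond the scatter). The estimate for compound 4 is 7000 nM, between 2000 nM and 25000 nM.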

Compound 4, half-maximal inhibitory concentration: 3950 nM
Compound 4: middle estimate off by 1.8-fold (0.25 log units), on the high side, and the stated range covers the measured number.
By their numbers in this assay, from the lowest: compounds 4 and 3 (each within the scatter of the next); then compounds 1 and 2 (each within the scatter of the next).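

In this assay, the ring nitrogen accepts a link other than a single carbon: the thiourea of compound 4, with its two chlorines on the aromatic ring, stays level with the dichlorobenzyl group (a 1.2-fold lower number from compound 3 to compound 4 (0.09 log units; within the scatter)). It also keeps the gain over the 2-fluorobenzyl group (a 5.5-fold lower number from compound 2 to compound 4 (0.74 log units; beyond the scatter)) and over the bare amine (a 4.7-fold lower number from compound 1 to compound 4 (0.67 log units; beyond the scatter)). Nothing measured here explains this result. Going by these compounds, whether a urea, with oxygen in place of the thiourea sulfur, would give a similar number stays open. So does the effect of a thiourea carrying an unsubstituted phenyl ring.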